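The source may hold more compounds than are shown below. What is called first, only, known or untested is meant among the compounds shown, and "the series" means these compounds.

Working notes on the series in a functional assay on NCI/ADR-RES cells (Homo sapiens) for antiproliferative activity, with a stated time of 48 h; on this read-out higher numbers stand for weaker inhibition of growth and lower numbers for stronger inhibition of growth. Compound 1 `Cc1cc(O)c(C2=NN(c3ccc(S(N)(=O)=O)cc3)C(c3ccccc3O)C2)cc1Cl` gives 14100 nM in this assay. Among the compounds with values here, compound 2 `Cc1cc(O)c(C2=NN(c3ccc(S(N)(=O)=O)cc3)C(/C=C/c3ccccc3)C2)cc1Cl` gives 22700 nM, and the only measured step so far is a 1.6-fold higher number from compound 1 to compound 2 (0.21 log units; within the scatter). Compound 2 thus carries the highest of the two numbers seen, with compound 1 its nearest neighbour inside the scatter, so no order between them can be claimed. Compound 3 `COc1ccc(C2CC(c3cc(Cl)c(C)cc3O)=NN2c2ccc(S(N)(=O)=O)cc2)c(OC)c1OC` is not yet measured; it differs from compound 2 in one place: 2,3,4-trimethoxyphenyl in place of 2-phenylethenyl on a saturated ring carbon. Within the data shown here, the single step that bears on this change is the exchange between 2-hydroxyphenyl and 2-phenylethenyl at the same saturated ring carbon, which stayed within the scatter; there is no measured step for a trimethoxyphenyl group. A step of a 1.5-fold lower number from compound 2 to compound 3 (0.18 log units; within the scatter) is expected, not beyond the scatter. Compound 3 is therefore estimated at 15000 nM, with a range from 6000 nM to 40000 nM.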

Compound 3, concentration for total growth inhibition: 7530 nM
The estimate for compound 3 lay 2.0-fold (0.30 log units) above the measured number; measured number inside the range.
By their numbers in this assay, from the lowest: compounds 3, 1 and 2 (each within the scatter of the next, the first and the last beyond it).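

Within the data shown here, at the saturated ring carbon next to the ring nitrogen, this assay now gives the first step beyond the scatter, though a modest one: a 3.0-fold lower number from compound 2 to compound 3 (0.48 log units; beyond the scatter) when 2,3,4-trimethoxyphenyl replaces 2-phenylethenyl, so the group at this carbon can shift the read-out. The replacement of 2-hydroxyphenyl by the same group gives a 1.9-fold lower number from compound 1 to compound 3 (0.27 log units; within the scatter), so 2,3,4-trimethoxyphenyl is separated only from 2-phenylethenyl and not from 2-hydroxyphenyl. No supporting data are available to explain either step.

The compounds shown leave open whether a phenyl carrying a single methoxy group would read like 2,3,4-trimethoxyphenyl, and how an amine or a carboxylic acid at this carbon would read. They also leave open whether the step from 2-phenylethenyl to 2,3,4-trimethoxyphenyl would hold with a different group in place of the 5-chloro-2-hydroxy-4-methylphenyl group.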